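Methoxy to Methyl on the Side Chain of Compound 2

A few compounds are considered here, and "the series" means these few. Any claim that something is new, unique, unknown or untested is made for them only; others in the source may bear on it.

Compound 1, `COc1cc(C(c2ccc(O)c(OC)c2)[C@H](C)[C@H](C)CF)ccc1O`: 75000 nM
Compound 2, `COC[C@H](C(C)C)C(c1ccc(O)c(OC)c1)c1ccc(O)c(OC)c1`: 76000 nM
Compound 3, `COc1cc(C(c2ccc(O)c(OC)c2)[C@@H](CO)C(C)C)ccc1O`: > 100000 nM

Three compounds that share a core and differ only in the group on the saturated chain carbon bound to two aromatic carbons have been tested in a functional assay on HeLa cells (Homo sapiens) for cytotoxicity, read by WST assay, with a stated time of 48 h; on this read-out lower numbers stand for stronger inhibition and higher numbers for weaker inhibition. Compound 1 gives 75000 nM and compound 2 gives 76000 nM; the step of a 1.0-fold higher number from compound 1 to compound 2 (0.01 log units; within the scatter) is within the scatter, so the two sit together. For compound 3 the assay reports only a limit, > 100000 nM, which is the limit of > 100000 nM in this assay, at which 1 of the 3 values shown sits.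

Compound 4, `CC[C@H](C(C)C)C(c1ccc(O)c(OC)c1)c1ccc(O)c(OC)c1`, is not yet measured. It differs from compound 2 by methyl in place of methoxy on a saturated chain carbon, three bonds along the chain from two aromatic carbons. Within the data shown here, the steps that bear on this are those among compounds 1, 2 and 3, where groups on that same chain carbon were exchanged: a 1.0-fold higher number from compound 1 to compound 2 (0.01 log units; within the scatter), an at least 1.3-fold higher number from compound 2 to compound 3 (0.11 log units; that floor lies within the scatter) and an at least 1.3-fold higher number from compound 1 to compound 3 (0.12 log units; that floor lies within the scatter), none of them beyond the scatter. The side-chain exchanges seen so far have left the read-out where it was, so compound 4 is expected to show no step beyond the scatter, a 1.1-fold higher number from compound 2 to compound 4 (0.02 log units; within the scatter). Compound 4 is therefore estimated at 80000 nM, between 40000 nM and 160000 nM.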

Compound 4, half-maximal inhibitory concentration: 9700 nM
Compound 4: the middle estimate sits 8.2-fold (0.92 log units) above what was measured; measured number outside the range, below it.
By their numbers in this assay, from the lowest: compound 4; then compounds 1 and 2 (each within the scatter of the next). At a limit, above all of these: compound 3.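

In this assay, among these compounds, this exchange is the first on the side chain to move the read-out beyond the scatter: methyl in place of methoxy gives a 7.8-fold lower number from compound 2 to compound 4 (0.89 log units; beyond the scatter), and 1-isopropylpropyl in place of 2-(fluoromethyl)-1-methylpropyl gives a 7.7-fold lower number from compound 1 to compound 4 (0.89 log units; beyond the scatter). With 1-isopropylpropyl in place of 1-(hydroxymethyl)-2-methylpropyl the step is an at least 10-fold lower number from compound 3 to compound 4 (1.01 log units; beyond the scatter), and that figure is only a floor. Compound 3 is known only as a limit: the limit of > 100000 nM in this assay, at which 1 of the 4 values shown sits.

Compound 4 is the only one of the four without oxygen or fluorine on the side chain, but one compound cannot show whether that absence accounts for its lower number. The compounds shown leave open how a longer chain such as propyl, or an amine or a carboxylic acid at this place, would read in this assay.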